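The source may report more compounds than this note shows. Statements on the series, on what has been measured and on what is new or still open speak of the compounds shown alone.

Two compounds have been run so far in a functional assay on HEK293 cells with D(4) dopamine receptor (Homo sapiens) as the target, read by FLIPR; on this read-out lower numbers stand for smaller maximal responses and higher numbers for larger maximal responses. Compound 1 `N#Cc1cccc(/C(CCN2CCN(c3ccccn3)CC2)=N/O)c1` gives 48%. Compound 2 `CCO/N=C(\CCN1CCN(c2ccccc2)CC1)c1ccccc1` gives 80%, the highest of the two numbers; its nearest neighbour is compound 1, whose number lies beyond the scatter below it. Within the data shown here, no pair among the measured compounds differs in one place only, so no single structural step has yet been characterised.

Compound 3 `CCO/N=C(\CCN1CCN(c2cccc(OCC)c2)CC1)c1ccccc1` has not been measured. It differs from compound 2 by ethoxy in place of hydrogen on an aromatic carbon; the place is on an aromatic carbon of a six-membered aromatic ring of carbon only, meta to a large group, and the same difference cut one bond further out reads phenyl to 3-ethoxyphenyl. Among the measured compounds shown here, nothing measured so far shows what an ethoxy group at such a place does, so the expectation rests on compound 2 alone. The step of a number 5 percentage points lower from compound 2 to compound 3 (within the scatter) is expected to be small, most likely within the scatter, with a slight lean downward. Compound 3 is therefore expected to give about 75%, with a range from 50% to 95%.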

Compound 3, largest response reached (reported as efficacy), in percent of the reference or control that the assay uses: 84%
Compound 3: middle estimate off by 9 percentage points, on the low side; the measured number falls inside the stated range.
By their numbers in this assay, from the lowest: compound 1; then compounds 2 and 3 (each within the scatter of the next).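

In this assay, the step of a number 4 percentage points higher from compound 2 to compound 3 (within the scatter) gives the series its first comparison of compounds that differ in one place. It shows that ethoxy in place of hydrogen on an aromatic carbon of this six-membered ring, meta to a large group, is tolerated in this read-out: the change from phenyl to 3-ethoxyphenyl, which adds 3 heavy atoms and 1 hydrogen-bond acceptor, leaves the maximal response of compound 3 within the scatter of that of compound 2. The data offer no explanation for this result, and a single step at a single place establishes no trend.

Open, going by these compounds, is whether the same tolerance holds for other groups at this place, such as a longer chain like butoxy, an amine or a carboxylic acid, or for ethoxy elsewhere on the ring. Also open, on these data alone, is which structural feature separates compound 1 from the other two compounds, since compound 1 differs from each of them in more than one place and no single change can be tied to its value of 48%.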